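Series notes: cytotoxicity and a bromo-for-hydrogen step

A few compounds are considered here, and "the series" means these few. Any claim that something is new, unique, unknown or untested is made for them only; others in the source may bear on it.

Compound 1 `Cc1ccc(C2CN(S(=O)(=O)c3ccc4c(c3)CCC4)C(=O)N2)cc1` defines the shared core of the series. In a functional assay on A549 cells (Homo sapiens) for cytotoxicity (on this read-out higher numbers stand for weaker inhibition and lower numbers for stronger inhibition), compound 1 gives 99200 nM. Compound 2 `Cc1ccc(S(=O)(=O)N2C(=O)NCC2c2ccccc2)cc1` reaches only a limit of the assay in this assay, namely > 316000 nM. Compound 3 `O=C1NCC(c2ccc(Br)cc2)N1S(=O)(=O)c1ccc2c(c1)CCC2` likewise gives only a limit in this assay, > 237000 nM. Compound 2 thus stands at one of the two limits shown here, (the limit of > 316000 nM in this assay, at which 1 of the 3 values shown sits), and no number is known for it. Compound 3 sits at the other limit, (the limit of > 237000 nM in this assay, at which 1 of the 3 values shown sits). Compound 4 `Cc1ccc(S(=O)(=O)N2C(=O)NCC2c2ccc(Br)cc2)cc1` is the next member: bromo in place of hydrogen on an aromatic carbon. Among the compounds with values here, no measured pair differs in one place, so the size of the change from compound 2 to compound 4 in this assay cannot be read from measured data. Given that compound 2 gives > 316000 nM, no step beyond the scatter is expected, and the estimate means a step of a number no higher from compound 2 to compound 4 (the limit leaves the size open). Compound 4 is expected to give about 316000 nM, between 100000 nM and 1000000 nM, most likely reported again only as a limit.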

Compound 4, half-maximal inhibitory concentration: 67000 nM
For compound 4 the middle estimate is 4.7-fold (0.67 log units) above the measured one; measured number outside the range, below it.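

Phenyl to 4-bromophenyl is the first single-place change that can be read in this series, and in this assay it gives an at least 4.7-fold lower number from compound 2 to compound 4 (0.67 log units; beyond the scatter), so the aromatic carbon para to a large group is a place where a bromo can move the read-out toward stronger inhibition. Going by these compounds, compound 2 stands at a limit, so the full size of this step stays open: the limit of > 316000 nM in this assay, at which 1 of the 4 values shown sits. The 4-bromophenyl group does not bring a measured number everywhere. Compound 4 differs in one place on the sulfonyl side from compound 3, and compound 3 stays at a limit, > 237000 nM.

On these data alone, whether the step belongs to bromo itself or would follow from any group on this carbon remains open. A chloro, a methoxy, an amine or a carboxylic acid at the same place would separate the two readings.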